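Ester for Amide on the Ketone Core

The source may hold more compounds than are shown below. What is called first, only, known or untested is meant among the compounds shown, and "the series" means these compounds.

Two pairs of compounds share one structural change, made on two different cores. Compound 1 is `NC(=O)c1ccc(-c2cnc(C(O)CCc3ccc(-c4ccccc4)cc3)o2)nc1` and compound 2 is `COC(=O)c1cccc(-c2cnc(C(O)CCc3ccc(-c4ccccc4)cc3)o2)n1`. In an assay for inhibition of Fatty-acid amide hydrolase 1 (Rattus norvegicus) (a higher number here means a weaker inhibitor, a lower number a stronger inhibitor), compound 1 gives only a limit, > 1000 nM, and not a number. In this assay compound 2 gives 9000 nM. The change between them is 6-(methoxycarbonyl)pyridin-2-yl in place of 5-carbamoylpyridin-2-yl on an aromatic carbon. The step that the limit leaves unreadable from compound 1 to compound 2 cannot be sized because compound 1 sits at the limit of > 1000 nM in this assay, at which 1 of the 3 values shown sits.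

Compound 3 is `NC(=O)c1ccc(-c2cnc(C(=O)CCc3ccc(-c4ccccc4)cc3)o2)nc1`. How its core differs from the core of compound 1 is not broken down here. In this assay compound 3 gives 1.3 nM, the lowest of the two numbers shown, with compound 2 standing far higher, beyond the usual scatter.

Compound 4 is `COC(=O)c1cccc(-c2cnc(C(=O)CCc3ccc(-c4ccccc4)cc3)o2)n1` and has not yet been measured. It differs from compound 3 by 6-(methoxycarbonyl)pyridin-2-yl in place of 5-carbamoylpyridin-2-yl on an aromatic carbon, the same change as from compound 1 to compound 2, at the same place on the shared five-membered ring. Since the first pair gives no readable size, the expectation rests on compound 3 giving 1.3 nM and on compound 2 still giving a number, 9000 nM, rather than a limit after the same change. The step of a 3.8-fold higher number from compound 3 to compound 4 (0.59 log units; beyond the scatter) is expected to be modest. Compound 4 is expected to give 5 nM in this assay, between 1 nM and 40 nM.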

Compound 4, inhibition constant: 1.2 nM
Estimate against measurement, compound 4: 4.2-fold (0.62 log units) above; low and high end bracket the measured number.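

In this assay, putting 6-(methoxycarbonyl)pyridin-2-yl in place of 5-carbamoylpyridin-2-yl on the core of compound 3 gives a 1.1-fold lower number from compound 3 to compound 4 (0.03 log units; within the scatter), so on this core the two groups cannot be told apart in this measurement. Whether the core of compound 1 behaves the same way cannot be read, since compound 1 gives only a limit and not a number, which leaves the step to compound 2 without a size: the limit of > 1000 nM in this assay, at which 1 of the 4 values shown sits. The result therefore shows that the change is tolerated on one core, but it does not show that the change has the same effect on both cores, and one readable pair is no rule for the series.

The two groups differ both in the function they carry, an amide against a methyl ester, and in the number at which it stands on the pyridine ring, so the compounds shown leave open which of these matters, or whether the two happen to cancel on the core of compound 3. Also open, as far as these compounds go, is how a carboxylic acid or a 5-(methoxycarbonyl)pyridin-2-yl group would compare with these two groups on either core.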